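The source may report more compounds than this note shows. Statements on the series, on what has been measured and on what is new or still open speak of the compounds shown alone.

Of the compounds shown here, two have been measured in an assay on isolated protein for inhibition of sodium- and chloride-dependent glycine transporter 1 (Homo sapiens); on this read-out lower numbers stand for stronger inhibition and higher numbers for weaker inhibition. Compound 1 `CC(C)S(=O)(=O)N1C[C@@H]2[C@H](C1)[C@@]2(CNC(=O)c1ccc(Cl)cc1Cl)CC1CC1` gives 3400 nM in this assay. Compound 2 `Cn1cnc(S(=O)(=O)N2C[C@@H]3[C@H](C2)[C@@]3(CNC(=O)c2c(Cl)cccc2Cl)CC2CC2)c1` gives 28 nM in this assay, the lower of the two numbers, and the gap from compound 1 to compound 2 is far beyond the usual scatter. The two compounds differ in two places at once, so no single change can be credited for that gap.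

Compound 3 `Cn1cnc(S(=O)(=O)N2C[C@@H]3[C@H](C2)[C@@]3(CNC(=O)c2ccc(Cl)cc2Cl)CC2CC2)c1` keeps the sulfonyl group of compound 2 and changes only the amide side: 2,4-dichlorophenyl in place of 2,6-dichlorophenyl on a carbonyl carbon. Among the measured compounds shown here, no measured pair shows this change alone, so the expectation rests on compound 2 alone. A modest loss, going from compound 2 to compound 3, of about a 3.2-fold higher number from compound 2 to compound 3 (0.51 log units; beyond the scatter) in this assay is expected, though a step within the scatter cannot be ruled out. Compound 3 is expected to give about 90 nM, with a likely range from 20 nM to 600 nM.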

Compound 3, half-maximal inhibitory concentration: 4 nM
Compound 3: middle estimate off by 23-fold (1.35 log units), on the high side; measured number outside the range, below it.
By their numbers in this assay, from the lowest: compound 3; then compound 2; then compound 1.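

In this assay the amide side matters even though its atoms stay the same: 2,4-dichlorophenyl in place of 2,6-dichlorophenyl on a carbonyl carbon gives a 7.0-fold lower number from compound 2 to compound 3 (0.85 log units; beyond the scatter) and so shows that the arrangement of the two chlorines alone moves the number beyond the scatter. Compound 3 also separates out the sulfonyl side, which compound 1 and compound 2 could not do, and 1-methyl-1H-imidazol-4-yl in place of isopropyl on a sulfonyl sulfur gives an 850-fold lower number from compound 1 to compound 3 (2.93 log units; beyond the scatter) as a much larger step than the one on the amide side. Nothing available here explains why either change acts as it does.

Still open, going by these compounds, is whether a phenyl ring with a single chlorine, or with trifluoromethyl in place of a chlorine, would keep the number this low. On these data alone, it is equally open whether a pyridine ring or a cyclopropyl group on the sulfonyl sulfur would do as well as 1-methyl-1H-imidazol-4-yl.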